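A few compounds are considered here, and "the series" means these few. Any claim that something is new, unique, unknown or untested is made for them only; others in the source may bear on it.

For the measured compounds named here, compound 2, with the structure `CCNC(=O)/C=C(C)/C=C/CC(C)CCCC(C)C`, is one of two compounds measured in a physicochemical assay for lipophilicity; on this read-out higher numbers stand for higher lipophilicity and lower numbers for lower lipophilicity. In this assay compound 2 gives 5.24, the lower of the two numbers. Compound 1, with the structure `CC(/C=C/CC(C)CCCC(C)C)=C\C(=O)O`, gives 5.95 in this assay, and the step of a number 0.71 log units lower from compound 1 to compound 2 (beyond the scatter) shows how far apart they stand. The single difference between them is ethylamino in place of hydroxy on a carbonyl carbon.

Compound 3, with the structure `CCCC(=O)/C=C(C)/C=C/CC(C)CCCC(C)C`, has not been measured in this assay. The change from compound 2 is propyl in place of ethylamino on a carbonyl carbon. The group that leaves carries one hydrogen-bond donor and the group that enters none. Going by the values given here, only the step from compound 1 to compound 2 bears on this change, and it concerns the ethylamino group arriving, not a propyl group taking its place, so no measured step tells directly what a propyl on this carbonyl carbon does. On that basis compound 3 is expected to give about 6.4 in this assay, within a range from 5.9 to 6.9. That estimate for compound 3 means a rise of a number 1.16 log units higher from compound 2 to compound 3 (beyond the scatter).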

Compound 3, partition coefficient: 6.81
Estimate against measurement, compound 3: 0.41 log units below, and the stated range covers the measured number.
By their numbers in this assay, from the lowest: compound 2; then compound 1; then compound 3.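

In this assay, propyl in place of ethylamino on a carbonyl carbon gives a number 1.57 log units higher from compound 2 to compound 3 (beyond the scatter), a large step between two groups that have the same count of heavy atoms but differ in that ethylamino carries a hydrogen-bond donor and propyl none. Propyl in place of hydroxy on the same carbonyl carbon gives a number 0.86 log units higher from compound 1 to compound 3 (beyond the scatter), so this position has now been read with a third group, and among the three compounds propyl gives the highest number and ethylamino the lowest, each gap beyond the scatter. Nothing available here explains the size of either step.

The compounds shown leave open how much of the large step goes with the loss of the amide hydrogen and how much with carbon taking the place of nitrogen, a question that a dimethylamino group on this carbonyl carbon would help to separate. They also leave open whether a longer chain such as butyl or pentyl on this carbonyl carbon would carry the number further up or leave it where propyl puts it.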